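Moving the phenyl ring off the oxazole onto a methylene

This account rests on a few compounds, and the source may have more. Where it says the series, first, only, none or still open, it means among the compounds named here.

Of the compounds shown here, three that share one core have been measured in an in vitro functional assay on cells for antagonist activity at transient receptor potential cation channel subfamily V member 1 (Homo sapiens), read by FLIPR and calcium flux; a lower number here means a stronger inhibitor, a higher number a weaker inhibitor. Compound 1 `Cc1cccc(-c2cnc(Nc3cccc4c3CC(O)CC4)o2)c1` gives 157 nM. Compound 2 `Cc1ccc(-c2cnc(Nc3cccc4c3CC(O)CC4)o2)cc1` gives 62 nM, and compound 3 `CC(C)(C)c1ccc(-c2cnc(Nc3cccc4c3CC(O)CC4)o2)cc1` gives 26 nM. Among these three numbers compound 2 holds the middle place: the step from compound 1 to compound 2 was a 2.5-fold lower number from compound 1 to compound 2 (0.40 log units; beyond the scatter), and the step from compound 2 to compound 3 was a 2.4-fold lower number from compound 2 to compound 3 (0.38 log units; beyond the scatter). Both steps were modest and both concerned only the methyl group on the outer phenyl ring, first its position and then its size.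

Compound 4 `OC1CCc2cccc(Nc3ncc(Cc4ccccc4)o3)c2C1` differs from compound 2 in another way: benzyl in place of 4-methylphenyl on an aromatic carbon. The outer ring itself is kept, but it is now carried on a one-carbon link rather than sitting directly on the five-membered ring. Within the data shown here, no measured step tests a change of this kind, so the two steps that are known say little about it beyond showing that small changes around this ring move this assay by modest amounts. The expectation is therefore loose. Compound 4 is estimated to give 300 nM, within a range from 60 nM to 1500 nM. This estimate means a step of a 4.8-fold higher number from compound 2 to compound 4 (0.68 log units; beyond the scatter) from compound 2 to compound 4, which is expected but not firmly grounded.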

Compound 4, half-maximal inhibitory concentration: 1820 nM
Estimate against measurement, compound 4: 6.1-fold (0.78 log units) below, and the stated range ends below it.
By their numbers in this assay, from the lowest: compound 3; then compound 2; then compound 1; then compound 4.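

In this assay, among these compounds, the position next to the ring oxygen proves far less tolerant of this change than the earlier steps suggested: replacing 4-methylphenyl with benzyl gives a 29-fold higher number from compound 2 to compound 4 (1.47 log units; beyond the scatter) and stands as a large step, whereas the changes among compounds 1, 2 and 3 were modest. Replacing 3-methylphenyl with benzyl points the same way, with a 12-fold higher number from compound 1 to compound 4 (1.06 log units; beyond the scatter) and again a large step, so both methylphenyl compounds compared here lie well on the stronger side of compound 4 even though the entering and leaving groups have the same heavy-atom count and the same kind of aromatic ring; how the outer ring is joined to the core therefore matters here, not merely whether that ring is present. No supporting measurement explains why this change costs so much.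

The change also removes the methyl group from the outer ring, and the compounds shown cannot separate that loss from the effect of the methylene link. A plain phenyl group attached directly to the core, a 4-methylbenzyl or 4-tert-butylbenzyl group, and a longer chain such as phenethyl would each help to separate these effects.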